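The source may report more compounds than this note shows. Statements on the series, on what has been measured and on what is new or still open speak of the compounds shown alone.

Measured compounds:
compound 1 `CCCc1nc(-c2ccccc2)c(CNCCN2CCN(c3ccc(Cl)cc3)CC2)o1` – 2820 nM
compound 2 `CCCc1nc(-c2ccccc2)c(CNCCN2CCN(c3ccc(F)cc3)CC2)o1` – 7080 nM
compound 3 `CCCc1nc(-c2ccccc2)c(CNCCN2CCN(C(c3ccccc3)c3ccccc3)CC2)o1` – 7470 nM

These three compounds share one core and differ only in the group attached to the far end of the piperazine ring. In an assay on HEK293 cells for inhibition of Voltage-dependent T-type calcium channel subunit alpha-1G (Homo sapiens), read by patch clamp (on this read-out lower numbers stand for stronger inhibition and higher numbers for weaker inhibition), compound 2 stands second highest of the three numbers; its nearest neighbour is compound 3, whose value lies within the scatter of compound 2, while compound 1 sits furthest away with a clearly lower number.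

Compound 4 `CCCc1nc(-c2ccccc2)c(CNCCN2CCN(c3ccc(C(F)(F)F)cc3)CC2)o1` has not yet been measured. It differs from compound 2 in one place: trifluoromethyl in place of fluoro on an aromatic carbon, on an aromatic carbon of a six-membered aromatic ring of carbon only, para to a large group.

Going by the values given here, only one measured step touches this same position: a 2.5-fold higher number from compound 1 to compound 2 (0.40 log units; beyond the scatter). That step shows that exchanging one small substituent for another at this carbon moved the number by a modest amount in this assay. Among the compounds with values here, no measured pair covers a trifluoromethyl group here, so the direction for compound 4 rests on that single step alone, and the expected shift is kept modest. The estimate for compound 4 is 3200 nM, with a range from 1100 nM to 9500 nM, which means an expected step of a 2.2-fold lower number from compound 2 to compound 4 (0.34 log units; beyond the scatter).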

Compound 4, half-maximal inhibitory concentration: 1300 nM
Compound 4: the middle estimate sits 2.5-fold (0.39 log units) above what was measured; measured number inside the range.
By their numbers in this assay, from the lowest: compound 4; then compound 1; then compounds 2 and 3 (each within the scatter of the next).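

In this assay, going by these compounds alone, the aromatic carbon para to a large group turns out to allow more than the earlier compounds showed, with trifluoromethyl in place of fluoro giving a 5.4-fold lower number from compound 2 to compound 4 (0.74 log units; beyond the scatter). Trifluoromethyl in place of chloro gives a 2.2-fold lower number from compound 1 to compound 4 (0.34 log units; beyond the scatter), so the three groups at this carbon now fall into a clear order, with every step beyond the scatter: trifluoromethyl has the lowest number, chloro the next, and fluoro the highest. Within the data shown here, the single earlier step at this carbon showed only that chloro gave a lower number than fluoro, whereas compound 4 shows that another group can go lower still, which on this read-out means stronger inhibition.

Nothing available here bears on what lies behind this order, so the three groups give a ranking and not an explanation. As far as these compounds go, how a nitrile, a methoxy group or a plain hydrogen at this same carbon would compare with these three stays open, as does whether trifluoromethyl would give a similar step with a longer chain in place of the propyl group on the shared core.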